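The source may report more compounds than this note shows. Statements on the series, on what has been measured and on what is new or still open speak of the compounds shown alone.

Measured so far:
compound 1, `CCOC(=O)c1csc(CO/N=C(\C)c2ccc(Sc3cc(F)cc(C4CCOCC4)c3)cc2)n1`, 150 nM
compound 2, `C/C(=N\O)c1ccccc1Sc1cc(F)cc(C2CCOCC2)c1`, > 10000 nM
compound 3, `COC1(c2csc(Sc3ccc4c(c3)OCC/C4=N\O)c2)CCOCC1`, 40 nM

In a functional assay (blood) for inhibition, with Homo sapiens as the target (a lower number here means a stronger inhibitor, a higher number a weaker inhibitor), compound 1 gives 150 nM, the higher of the two numbers shown. Compound 3 gives 40 nM, and the gap to compound 1 lies beyond the usual scatter. Compound 2 gives only a limit, > 10000 nM, not a number. Compound 4, `C/C(=N\OCC#N)c1ccc(Sc2cc(F)cc(C3CCOCC3)c2)cc1`, has not yet been measured in this assay. It differs from compound 1 in one place: cyano in place of 4-(ethoxycarbonyl)-1,3-thiazol-2-yl on a saturated chain carbon bound to an oxygen on an unsaturated carbon. Within the data shown here, no pair of measured compounds differs in a single place, so no measured step guides this change. A modest move toward a higher number is expected, a 2.0-fold higher number from compound 1 to compound 4 (0.30 log units; within the scatter). Compound 4 is therefore expected to give about 300 nM, within a range from 60 nM to 1500 nM.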

Compound 4, half-maximal inhibitory concentration: 20 nM
The estimate for compound 4 lay 15-fold (1.18 log units) above the measured number; the whole stated range lies above it.
By their numbers in this assay, from the lowest: compounds 4 and 3 (each within the scatter of the next); then compound 1. At a limit, above all of these: compound 2.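

In this assay, cyano in place of 4-(ethoxycarbonyl)-1,3-thiazol-2-yl gives a 7.5-fold lower number from compound 1 to compound 4 (0.88 log units; beyond the scatter) in this single pair. At this position, then, the thiazole ester is not needed for a low number: a group of far fewer heavy atoms, with no ring, gives a stronger inhibitor. Nothing shown here explains the change. Left open is how an amine or a carboxylic acid on this chain carbon would compare with cyano, and whether a longer chain carrying the cyano would hold the gain.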